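A larger ester tail on the shared core

A few compounds are considered here, and "the series" means these few. Any claim that something is new, unique, unknown or untested is made for them only; others in the source may bear on it.

Compound 1 `Cc1ncc([N+](=O)[O-])n1CCSC(=S)N1CCC2(CC1)OCCO2` gives only a limit in an ADME assay on HeLa cells (Homo sapiens) for cytotoxicity (a higher number here means a weaker inhibitor, a lower number a stronger inhibitor), at > 1000 ug/mL. Compound 2 `Cc1ncc([N+](=O)[O-])n1CCSC(=S)N1CCC(C)CC1` gives 190 ug/mL in this assay. Compound 3 `Cc1ncc([N+](=O)[O-])n1CCSC(=S)N1CCC(OC(=O)C(Cl)Cl)CC1` again reaches only the limit, at > 1000 ug/mL in this assay. The step of an at least 5.2-fold higher number from compound 2 to compound 3 (0.72 log units; beyond the scatter) is therefore known only as a bound, and compound 3 stands at the limit of > 1000 ug/mL in this assay, at which 2 of the 3 values shown sit. Compound 4 `Cc1ncc([N+](=O)[O-])n1CCSC(=S)N1CCC(OC(=O)CSC(=S)N2CCCCC2)CC1` differs from compound 3 by a group of 10 heavy atoms (7 carbon, 1 nitrogen, 2 sulfur; one six-membered non-aromatic ring with 1 hetero atom) in place of a group of 3 heavy atoms (1 carbon, 2 chlorine; no ring), on a carbonyl carbon. For the measured compounds named here, no measured step touches that change directly; the only step on the same saturated ring carbon, an at least 5.2-fold higher number from compound 2 to compound 3 (0.72 log units; beyond the scatter), carried a compound from a number up to the limit, and most of the measured values sit at that limit. Compound 4 is therefore expected either to give a weak number near the top of the range or to sit at the limit once more, so that an at least 1.2-fold lower number from compound 3 to compound 4 (0.09 log units; that floor lies within the scatter) is expected to lie within the scatter. The estimate for compound 4 in this assay is 800 ug/mL, between 250 ug/mL and 2000 ug/mL.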

Compound 4, half-maximal inhibitory concentration: 980 ug/mL
The estimate for compound 4 lay 1.2-fold (0.09 log units) below the measured number; the measured number falls inside the stated range.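

In this assay, putting the larger group with its six-membered non-aromatic ring in place of dichloromethyl on the carbonyl carbon gives an at least 1.0-fold lower number from compound 3 to compound 4 (0.00 log units; that floor lies within the scatter), so this change can be read only as a floor that lies within the scatter. Compound 4 is the only ester shown that gives a number rather than a limit, yet that number stays high in the range and does not come close to compound 2 at 190 ug/mL. With both esters at the top of the range, the values shown remain crowded there: the limit of > 1000 ug/mL in this assay, at which 2 of the 4 values shown sit.

The compounds shown leave open whether the ester link or the group on its carbonyl carbon sets these high numbers. They also do not say how a hydroxyl or an amine on the same saturated ring carbon would read in this assay.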